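Compound 2 to compound 4: chloro in place of fluoro

The source may hold more compounds than are shown below. What is called first, only, known or untested is meant among the compounds shown, and "the series" means these compounds.

In a physicochemical assay for solubility (a higher number here means a more soluble compound, a lower number a less soluble compound), compound 2 (`Cc1cc(S(C)(=O)=O)cc2c1NNC(C(N)=O)=C2Nc1cncc(F)c1`) gives 37 ug/mL, the highest of the three numbers, against compound 1 (`Cc1cc(S(C)(=O)=O)cc2c1NNC(C(N)=O)=C2Nc1cccc(C#N)c1`) at 1 ug/mL and compound 3 (`CC(C)(C)S(=O)(=O)c1ccc2c(c1)C(Nc1cncc(F)c1)=C(C(N)=O)NN2`) at 1 ug/mL. Compound 4 (`Cc1cc(S(C)(=O)=O)cc2c1NNC(C(N)=O)=C2Nc1cncc(Cl)c1`) carries chloro in place of fluoro on an aromatic carbon. Among the measured compounds shown here, the one measured step bearing on this, a 37-fold higher number from compound 1 to compound 2 (1.57 log units; beyond the scatter), is large and beyond the scatter, but it exchanges a whole group on the amine nitrogen. For the measured compounds named here, no measured step covers this halogen exchange, so that step sets no size for it. A smaller downward change is expected, read as a 3.1-fold lower number from compound 2 to compound 4 (0.49 log units; beyond the scatter). For compound 4 the estimate is 12 ug/mL, with an expected range of 3 ug/mL to 35 ug/mL.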

Compound 4, solubility: 12 ug/mL
Estimate against measurement, compound 4: no gap at the digits printed, and the stated range covers the measured number.
By their numbers in this assay, from the lowest: compounds 1 and 3 (each within the scatter of the next); then compound 4; then compound 2.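

In this assay this aromatic carbon is sensitive to the choice of halogen: chloro in place of fluoro is a modest step (a 3.1-fold lower number from compound 2 to compound 4 (0.49 log units; beyond the scatter)). The 5-chloropyridin-3-yl group also keeps a large margin over 3-cyanophenyl (a 12-fold higher number from compound 1 to compound 4 (1.08 log units; beyond the scatter)), so that gain does not depend on fluoro alone. No measured evidence here accounts for either step. Open, going by these compounds, is where a methyl, a methoxy or an amine on this carbon would fall relative to the two halogens. Also open, on these data alone, is whether chloro in place of fluoro moves the number the same way on the core of compound 3.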